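A few compounds are considered here, and "the series" means these few. Any claim that something is new, unique, unknown or untested is made for them only; others in the source may bear on it.

The study measures inhibition of growth in a functional assay on 786-0 cells (Homo sapiens) for inhibition, read by sulforhodamine B assay, with a stated time of 48 h; on this read-out higher numbers stand for weaker inhibition of growth and lower numbers for stronger inhibition of growth. Compound 1, `COc1cc(-c2cc(/C=C/C(=O)c3ccc(Cl)c(Cl)c3)[nH]n2)cc(OC)c1OC`, gives 68000 nM, the highest number of the three measured compounds. Compound 2, `COc1ccc(-c2cc(/C=C/C(=O)c3ccc(N)cc3)[nH]n2)cc1OC`, gives 4390 nM, and compound 3, `COc1ccc(-c2cc(/C=C/C(=O)c3cc(OC)c(OC)c(OC)c3)[nH]n2)cc1OC`, gives 2900 nM. Both of these numbers lie below that of compound 1 by more than the scatter of repeated measurement, so compound 1 is the weakest inhibitor of growth among the three. For the measured compounds named here, neither compound 2 nor compound 3 differs from compound 1 in only one place, so no single step can be traced between the measured compounds.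

Compound 4, `COc1cc(-c2cc(/C=C/C(=O)c3ccc(F)c(F)c3)[nH]n2)cc(OC)c1OC`, differs from compound 1 in one place: 3,4-difluorophenyl in place of 3,4-dichlorophenyl on a carbonyl carbon. Going by the values given here, no measured pair tests this exchange, so its effect is open. Since compound 1 gives 68000 nM, compound 4 is expected to remain in a similar region, with an expected step of a 1.5-fold lower number from compound 1 to compound 4 (0.18 log units; within the scatter) in this assay, modest and close to the scatter. The estimate for compound 4 is 45000 nM, with a range from 12000 nM to 150000 nM.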

Compound 4, concentration for total growth inhibition: 15700 nM
Compound 4: middle estimate off by 2.9-fold (0.46 log units), on the high side; measured number inside the range.
By their numbers in this assay, from the lowest: compounds 3 and 2 (each within the scatter of the next); then compound 4; then compound 1.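

For the compounds shown here, the exchange of 3,4-dichlorophenyl for 3,4-difluorophenyl on a carbonyl carbon provides the first single-place comparison in this assay, with a 4.3-fold lower number from compound 1 to compound 4 (0.64 log units; beyond the scatter). This shows that the position is sensitive to the exchange: with the rest of compound 1 unchanged, replacing chlorine with fluorine on this ring moves the number beyond the scatter, towards stronger inhibition of growth. No measurement offered here accounts for the size or direction of this step.

The compounds shown leave open whether a plain phenyl, or a phenyl bearing a nitrile or trifluoromethyl group, would give a lower or higher number at this place. They also leave open whether the same exchange would produce a similar step on the core of compound 2.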